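A few compounds are considered here, and "the series" means these few. Any claim that something is new, unique, unknown or untested is made for them only; others in the source may bear on it.

Compound 1 `O=C(O)CC(Cc1nc2cc(Cl)ccc2[nH]1)c1ccc(Cl)cc1` is tested in an assay on isolated protein for inhibition of protein kinase C zeta type (Homo sapiens), read by 33P incorporation, tested at 50 uM (a lower number here means a weaker effect, a higher number a stronger effect of the compound at the concentration tested), and in it compound 1 gives 0%. Two close relatives share its core: compound 2 `O=C(O)CC(Cc1nc2cc(C(=O)O)ccc2[nH]1)c1ccc(Cl)cc1` gives 0% in this assay, and compound 3 `N#Cc1ccc2[nH]c(CC(CC(=O)O)c3ccc(Cl)cc3)nc2c1` gives 0%. The three results lie level with one another: from compound 1 to compound 2 there is no change at the digits printed from compound 1 to compound 2 (within the scatter), from compound 1 to compound 3 there is no change at the digits printed from compound 1 to compound 3 (within the scatter), and from compound 2 to compound 3 there is no change at the digits printed from compound 2 to compound 3 (within the scatter). None of these compounds shows any inhibition at the concentration used.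

Compound 4 `O=C(O)CC(Cc1nc2cc(Cl)c(F)cc2[nH]1)c1ccc(Cl)cc1` has not yet been tested. Its difference from compound 1 is fluoro in place of hydrogen on an aromatic carbon. Each measured change on this same ring, a carboxy or a cyano group taking the place of the chloro, left the read-out unmoved. Adding a single fluorine is a smaller alteration than either of those, so the expectation is that compound 4 will also show nothing beyond the scatter. Compound 4 is therefore expected to give about 2%, within a range from -8% to 12%, which means an expected step of a number 2 percentage points higher from compound 1 to compound 4 (within the scatter).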

Compound 4, a percentage reported as inhibition, at one concentration (the size of the read-out at that concentration, not a potency): 35%
Compound 4: the middle estimate sits 33 percentage points below what was measured; measured number outside the range, above it.
By their numbers in this assay, from the lowest: compounds 1, 2 and 3 (each within the scatter of the next); then compound 4.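

In this assay, putting fluoro in place of hydrogen on an aromatic carbon ortho to a chloro group gives a step of a number 35 percentage points higher from compound 1 to compound 4 (beyond the scatter). The earlier compounds shown here changed only the group at the chloro position, and their results stayed level, so they gave no sign that this series could register at all in this read-out; compound 4 shows that a change of a single heavy atom, at a different ring position, can lift it clearly off zero. Nothing measured here explains why so small a change has so large an effect.

Fluoro is the only group shown at this position, so it remains open whether a methyl group, a methoxy group or an amine on the same carbon would raise the read-out too. It also remains open whether the step from fluoro depends on the neighbouring chloro group, since every fluoro result shown comes with that chloro group in place.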